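The compounds below may be only part of what the source reports. "The series", "measured", "known", "first", "only" and "open" are said of these compounds alone.

Working notes on the shared core of compound 1 `O=C(Nc1ccc(Cl)c(-c2nnc3c(Cl)cccn23)c1)c1ccccc1`, which carries phenyl on the carbonyl carbon. In a functional assay on MDA-MB-231 cells (Homo sapiens) for antiproliferative activity, read by MTT assay, with stated times of 72 h and 4 h (on this read-out lower numbers stand for stronger inhibition and higher numbers for weaker inhibition), compound 1 gives 58200 nM. Compound 2 `O=C(Nc1ccc(Cl)c(-c2nnc3c(Cl)cccn23)c1)c1c(F)cccc1Cl` returns only a limit of the assay, > 100000 nM. Compound 3 `Cc1cc(Cl)ccc1C(=O)Nc1ccc(Cl)c(-c2nnc3c(Cl)cccn23)c1` likewise returns only a limit, > 100000 nM. The step of an at least 1.7-fold higher number from compound 1 to compound 2 (0.23 log units; that floor lies within the scatter) and the step of an at least 1.7-fold higher number from compound 1 to compound 3 (0.23 log units; that floor lies within the scatter) both run upward, and the step that the two limits leave unreadable from compound 2 to compound 3 cannot be read because the limit of > 100000 nM in this assay, at which 2 of the 3 values shown sit, holds both of its values. Compound 2 therefore stands at the limit of this assay, with no numbered value of its own and only the floor of its step from compound 1 known.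

Compound 4 `CS(=O)(=O)c1ccc(C(=O)Nc2ccc(Cl)c(-c3nnc4c(Cl)cccn34)c2)cc1` differs from compound 2 in one place: 4-(methylsulfonyl)phenyl in place of 2-chloro-6-fluorophenyl on a carbonyl carbon. For the measured compounds named here, no measured step carries the 4-(methylsulfonyl)phenyl group; the only bearing is that both substituted phenyl groups so far ended at the limit while compound 1 sits a short way beneath it. Starting from a limit, no direction can be read, and the step of an at least 1.2-fold lower number from compound 2 to compound 4 (0.09 log units; that floor lies within the scatter) is expected to be none beyond the scatter. Compound 4 is expected to give 80000 nM in this assay, within 30000 nM to 200000 nM, with a fair chance that the assay again reports only a limit.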

Compound 4, half-maximal inhibitory concentration: > 100000 nM
Compound 4 ended at the assay's limit; the forecaster's own chance of this, stated with the estimate: 55%; middle value at least 1.2-fold (0.09 log units) away from the limit.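

The 4-(methylsulfonyl)phenyl group differs from the two earlier substituted phenyl groups in carrying hydrogen-bond acceptors, yet it too gives no numbered value in this assay, so compound 1 remains the only compound shown with one. Methylsulfonyl in place of hydrogen on an aromatic carbon gives an at least 1.7-fold higher number from compound 1 to compound 4 (0.23 log units; that floor lies within the scatter), so a real rise over compound 1 is not established. The steps among compound 2, compound 3 and compound 4 cannot be read, since all three stand at the same limit: the limit of > 100000 nM in this assay, at which 3 of the 4 values shown sit.

On these data alone, whether any group on the carbonyl carbon gives a clearly lower number than compound 1 stays open. Also open, as far as these compounds go, is whether a phenyl ring bearing an amine or a carboxylic acid, or a longer alkyl chain in place of the phenyl ring, would return a numbered value.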